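A few compounds are considered here, and "the series" means these few. Any claim that something is new, unique, unknown or untested is made for them only; others in the source may bear on it.

Values so far in an ADME assay on LLC-MK2 cells (Macaca mulatta) for cytotoxicity, read by MTT assay, with a stated time of 48 h (on this read-out higher numbers stand for lower toxicity in this test and lower numbers for higher toxicity in this test), are:

- compound 1 (`CC(=O)/C(C)=C/c1ccc([N+](=O)[O-])cc1`) gives 266000 nM
- compound 2 (`CC(=O)/C(C)=C/c1ccc(N(C)C)cc1`) gives 150000 nM
- compound 3 (`C/C(=C\c1ccccc1)C(=O)/C=C/c1ccccc1`) gives 33600 nM

Compound 3 at 33600 nM has the lowest number of the three and so shows the highest toxicity, and both other compounds sit beyond the usual scatter from it. Compound 4 (`C/C(=C\c1ccccc1)C(=O)/C=C/c1ccc(N(C)C)cc1`) differs from compound 3 in one place (dimethylamino in place of hydrogen on an aromatic carbon): dimethylamino in place of hydrogen on an aromatic carbon, para to a large group.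

Among the measured compounds shown here, only one measured step involves this group (a 1.8-fold lower number from compound 1 to compound 2 (0.25 log units; within the scatter)), and there dimethylamino replaced nitro, not hydrogen, on a different core. For the measured compounds named here, no measured step shows dimethylamino replacing hydrogen, so this guidance is indirect. On that basis, no shift beyond the scatter is expected in this assay and any small drift should be toward lower numbers. The estimated change is slight (a 1.1-fold lower number from compound 3 to compound 4 (0.05 log units; within the scatter)). For compound 4 the estimated value is 30000 nM (expected range 12000 nM to 75000 nM).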

Compound 4, half-maximal cytotoxic concentration: 53000 nM
Compound 4: middle estimate off by 1.8-fold (0.25 log units), on the low side; the range from low to high includes it.
By their numbers in this assay, from the lowest: compounds 3 and 4 (each within the scatter of the next); then compounds 2 and 1 (each within the scatter of the next).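

In this assay the swap of hydrogen for dimethylamino on an aromatic carbon, para to a large group, gives a step that stays within the scatter (a 1.6-fold higher number from compound 3 to compound 4 (0.20 log units; within the scatter)). Among the compounds shown here, this is the first direct reading of that swap, since the earlier step (a 1.8-fold lower number from compound 1 to compound 2 (0.25 log units; within the scatter)) put dimethylamino in place of nitro on a different core, and it shows that this position can carry the added group with no change that repeat measurements could separate from noise. No measurement available here explains this outcome.

From the compounds shown here alone, whether an amine with hydrogens on its nitrogen, such as a plain amino group, or a carboxylic acid in this same place would move the number beyond the scatter stays open. So does whether a longer chain on that nitrogen would do so.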